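Trifluoromethyl for Trifluoromethoxy on Two Related Cores

The source may hold more compounds than are shown below. What is called first, only, known or untested is meant among the compounds shown, and "the series" means these compounds.

Measured compounds:
Compound 1, `O=[N+]([O-])c1cn2c(n1)OC[C@H](OCc1ccc(-c3ccc(OC(F)(F)F)cc3Cl)cc1)C2`: 85%
Compound 2, `O=[N+]([O-])c1cn2c(n1)OC[C@H](OCC#Cc1ccc(-c3ccc(OC(F)(F)F)cc3)cn1)C2`: 68%
Compound 3, `O=[N+]([O-])c1cn2c(n1)OC[C@H](OCc1ccc(-c3ccc(C(F)(F)F)cc3Cl)cc1)C2`: 76%

In an ADME assay on microsomes from liver (Mus musculus, strain CD-1) for metabolic stability, with a stated time of 1 h (a higher number here means that more of the compound is left, a lower number that less of the compound is left), compound 1 gives 85%, compound 3 gives 76% and compound 2 gives 68%. Compound 2 and compound 3 lie within the scatter of each other, while compound 1 stands above compound 2 by more than the scatter. Compound 1 and compound 3 differ in one place, (trifluoromethyl in place of trifluoromethoxy on an aromatic carbon), and the step is a number 9 percentage points lower from compound 1 to compound 3 (within the scatter).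

Compound 4, `O=[N+]([O-])c1cn2c(n1)OC[C@H](OCC#Cc1ccc(-c3ccc(C(F)(F)F)cc3)cn1)C2`, has not been measured in this assay. It differs from compound 2 by trifluoromethyl in place of trifluoromethoxy on an aromatic carbon. This is the same kind of change as from compound 1 to compound 3, though not the same: in compound 1 the ring carrying the group also holds a chloro group, meta to the place of exchange, and in compound 2 it does not. How the core of compound 2 differs from the core of compound 1 is not broken down here.

Going by the values given here, the step expected from compound 2 to compound 4 in this assay is a number 8 percentage points lower from compound 2 to compound 4 (within the scatter), a size chosen to sit beside the measured one, because the step of a number 9 percentage points lower from compound 1 to compound 3 (within the scatter) is the only guide the data give for this exchange. Compound 4 is therefore estimated at 60%, with a range from 47% to 73% expected to hold most repeat measurements.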

Compound 4, percent of the compound remaining in the Mus musculus assay: 58%
Beside the measured number, compound 4's estimate is 2 percentage points above it; low and high end bracket the measured number.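

Putting trifluoromethyl in place of trifluoromethoxy gives, in the Mus musculus assay, a number 10 percentage points lower from compound 2 to compound 4 (within the scatter), and the step does not differ from the one seen on the other core: the same change on two cores in the Mus musculus assay, a number 9 percentage points lower (within the scatter) from compound 1 to compound 3 and a number 10 percentage points lower (within the scatter) from compound 2 to compound 4, 1 percentage points apart, within the scatter of two such steps. Neither step on its own stands clear of the scatter, so these two pairs show agreement on two cores, not a firm drop in the amount of compound left, and they give no rule for other cores in the series. In a physicochemical assay for solubility, read by HPLC, measured as kinetic solubility, with a stated time of 15 min, at pH 1 (on this read-out lower numbers stand for lower solubility and higher numbers for higher solubility), compound 2 gives 3 ug/mL and compound 4 gives 7.6 ug/mL. In the physicochemical assay the same exchange goes with a higher number, but that result rests on a single pair, on one core only: the measured solubility of compound 2, 3 ug/mL, and of compound 4, 7.6 ug/mL, a 2.5-fold higher number (0.40 log units; beyond the scatter).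

The compounds shown leave open whether the size of the step depends on the chloro group, which compound 1 and compound 3 carry and compound 2 and compound 4 do not, or on the other differences between the two cores. They also leave open how a methoxy group, a fluoro group or a nitrile would compare in the same place, para to a large group, and whether the result in the physicochemical assay would recur on the core of compound 1.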